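A Butyl Tail Removed in Two Related Series

This account rests on a few compounds, and the source may have more. Where it says the series, first, only, none or still open, it means among the compounds named here.

Compound 1 `CCCCCCCCCCCCCCN(NC(=O)COC)C(=O)CCCCCCCCC` and compound 2 `CCCCCCCCCCN(NC(=O)COC)C(=O)CCCCCCCCC` share one core, while compound 3 `CCCCCCCCCCCCCCNNC(=O)COC` and compound 4 `CCCCCCCCCCNNC(=O)COC` share another; the difference between the two cores is not broken down here. In a functional assay on HeLa cells (Homo sapiens) for cytotoxicity, with a stated time of 72 h (on this read-out lower numbers stand for higher toxicity in this test and higher numbers for lower toxicity in this test), compound 1 reaches only a limit, > 110000 nM. Compound 2 likewise shows only a limit, > 125000 nM. Compound 3, by contrast, gives a number, 59600 nM. From compound 1 to compound 2 the change is hydrogen in place of butyl on a saturated chain carbon, ten or more bonds along the chain from an amide-type nitrogen, and the step that the two limits leave unreadable from compound 1 to compound 2. From compound 3 to compound 4 the change is hydrogen in place of butyl on a saturated chain carbon, ten or more bonds along the chain from an amine nitrogen, the same kind of change, though here the chain is counted from an amine nitrogen rather than from an amide-type nitrogen. With the limit of > 110000 nM in this assay, at which 1 of the 3 values shown sits, and the limit of > 125000 nM in this assay, at which 1 of the 3 values shown sits, in place, the earlier step offers no size to carry over. For compound 4 the expected step is a 1.8-fold higher number from compound 3 to compound 4 (0.27 log units; within the scatter), leaning toward lower toxicity. Compound 4 is therefore estimated at 110000 nM, between 40000 nM and 300000 nM.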

Compound 4, half-maximal cytotoxic concentration: 138000 nM
For compound 4 the middle estimate is 1.3-fold (0.10 log units) below the measured one, and the stated range covers the measured number.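

In this assay, hydrogen in place of butyl gives a 2.3-fold higher number from compound 3 to compound 4 (0.36 log units; beyond the scatter), a modest shift toward lower toxicity, seen on the core of compound 3 alone. On the other core, compound 1 gives only a limit: the limit of > 110000 nM in this assay, at which 1 of the 4 values shown sits. Compound 2 also gives only a limit, so the matching step cannot be read and the result neither supports nor contradicts carrying this change from one core to the other: the limit of > 125000 nM in this assay, at which 1 of the 4 values shown sits.

The compounds shown leave open how a longer chain, or an amine or a carboxylic acid in place of the butyl, would read in this assay. They also leave open whether the step seen here would hold on any further core.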